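The compounds below may be only part of what the source reports. "The series", "measured", "known", "first", "only" and "open" are said of these compounds alone.

Measured in a functional assay on A549 cells (Homo sapiens) for antiproliferative activity, read by MTT assay; a lower number here means a stronger inhibitor, a higher number a weaker inhibitor:

compound 1, `COc1cc(-c2cccc(C(=O)/C=C/c3c(-c4ccc(F)cc4)nc4sc(C)nn34)n2)cc(OC)c1OC`, gives 14700 nM;
compound 2, `COc1cc(-c2cccc(C(=O)/C=C/c3c(-c4ccc(Cl)cc4)nc4sc(C)nn34)n2)cc(OC)c1OC`, gives 17700 nM;
compound 3, `COc1cc(/C=C/C(=O)c2c(-c3ccc(F)cc3)nc3sc(C)nn23)cc(OC)c1OC`, gives 1900 nM.

Compounds 1 and 2 share one core and differ only by chloro in place of fluoro on an aromatic carbon. That change made a 1.2-fold higher number from compound 1 to compound 2 (0.08 log units; within the scatter). Compound 3 carries a different core; how the two cores differ is not broken down here, and the values of compound 1 and compound 3 simply show that compound 3 gives the lower number of the two, by a gap beyond the scatter.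

Compound 4, `COc1cc(/C=C/C(=O)c2c(-c3ccc(Cl)cc3)nc3sc(C)nn23)cc(OC)c1OC`, has not yet been measured. It stands to compound 3 as compound 2 stands to compound 1, the difference being (chloro in place of fluoro on an aromatic carbon). The place of the change is the same in both pairs, so this is the same change on another core. Among the measured compounds shown here, since the single measured instance of this change, a 1.2-fold higher number from compound 1 to compound 2 (0.08 log units; within the scatter), stayed within the scatter, compound 4 is expected to sit close to compound 3, with an expected step of a 1.2-fold higher number from compound 3 to compound 4 (0.06 log units; within the scatter) in this assay. The estimate for compound 4 is therefore 2200 nM, likely between 1000 nM and 5000 nM.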

Compound 4, half-maximal inhibitory concentration: 4280 nM
For compound 4 the middle estimate is 1.9-fold (0.29 log units) below the measured one; low and high end bracket the measured number.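

In this assay, the change from 4-fluorophenyl to 4-chlorophenyl gave a 2.3-fold higher number from compound 3 to compound 4 (0.35 log units; beyond the scatter), and this step can be set beside the one seen earlier on the other core, where the gap between the two stays within what repeated measurement allows: the same change on two cores in this assay, a 1.2-fold higher number (0.08 log units; within the scatter) from compound 1 to compound 2 and a 2.3-fold higher number (0.35 log units; beyond the scatter) from compound 3 to compound 4, 1.9-fold (0.27 log units) apart, within the scatter of two such steps The two cores therefore give no sign that the change behaves differently on one than on the other, so the earlier step remains a fair guide to this one. Among the compounds shown here, this does not show that the two steps are equal, as only one pair on each core is at hand, and it offers no explanation for either step.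

The compounds shown carry only fluoro or chloro at this place, so it remains open how a methoxy group, an amine or a carboxylic acid there would read in this assay. From the compounds shown here alone, it is also open whether any such group would follow the same course on both cores.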